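Ring Size and a Halogen Swap in a Cytotoxicity Series

The source may report more compounds than this note shows. Statements on the series, on what has been measured and on what is new or still open speak of the compounds shown alone.

Measured compounds:
compound 1, `Fc1ccc(/C=N/c2sc3c(c2-c2nc4ccccc4s2)CCC3)cc1`: 302 ug/mL
compound 2, `Clc1ccc(/C=N/c2sc3c(c2-c2nc4ccccc4s2)CCC3)cc1`: 431 ug/mL
compound 3, `Fc1ccc(/C=N/c2sc3c(c2-c2nc4ccccc4s2)CCCC3)cc1`: 324 ug/mL

All three were tested in an ADME assay on HepG2 cells (Homo sapiens) for cytotoxicity, read by MTT assay, with a stated time of 72 h; on this read-out higher numbers stand for lower toxicity in this test and lower numbers for higher toxicity in this test. Compound 1 and compound 2 share one core and differ in a single place: chloro in place of fluoro on an aromatic carbon. That change gave a 1.4-fold higher number from compound 1 to compound 2 (0.15 log units; within the scatter), so the two compounds cannot be told apart on this read-out.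

Compound 3 carries a different core from compound 1; the difference between the two cores is not broken down here. In this assay compound 3 gives 324 ug/mL, and its values and those of compound 1 and compound 2 all lie close together.

Compound 4, `Clc1ccc(/C=N/c2sc3c(c2-c2nc4ccccc4s2)CCCC3)cc1`, has not yet been measured. It stands to compound 3 as compound 2 stands to compound 1: chloro in place of fluoro on an aromatic carbon. The place of the change is the same in both pairs, so this is the same change made on the other core. Since the first instance gave a 1.4-fold higher number from compound 1 to compound 2 (0.15 log units; within the scatter), the step from compound 3 to compound 4 is expected to be of similar size, a 1.3-fold higher number from compound 3 to compound 4 (0.11 log units; within the scatter), with no grounds in these three measurements for a larger shift. Compound 4 is therefore estimated at 420 ug/mL in this assay, in a range expected from 250 ug/mL to 700 ug/mL.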

Compound 4, half-maximal cytotoxic concentration: 397 ug/mL
Beside the measured number, compound 4's estimate is 1.1-fold (0.02 log units) above it, within the range that was stated.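

Placing chloro where fluoro stood on the core of compound 3 gave a 1.2-fold higher number from compound 3 to compound 4 (0.09 log units; within the scatter) in this assay, so compound 3 and compound 4 cannot be told apart on this read-out. Set beside the same change on the core of compound 1, the new step agrees with the earlier one, and in that limited sense the swap behaves alike on both cores: the same change on two cores in this assay, a 1.4-fold higher number (0.15 log units; within the scatter) from compound 1 to compound 2 and a 1.2-fold higher number (0.09 log units; within the scatter) from compound 3 to compound 4, 1.2-fold (0.07 log units) apart, within the scatter of two such steps. What carries over is the absence of a readable difference, so these two pairs do not show that going from 4-fluorophenyl to 4-chlorophenyl has any real effect on this read-out, and two cores are too few to predict what the swap would do on a third.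

The compounds shown have only fluoro or chloro at this place on the aromatic ring, and all four values lie close together, so it remains open whether a group of a different kind there, such as an amine, a carboxylic acid or a longer chain, would shift the number beyond the scatter. From the compounds shown here alone, it also remains open whether such a group would behave alike on both cores, which would be a sterner test of carrying a change from one core to another.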